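Antiproliferative activity across a small azetidinone series

A few compounds are considered here, and "the series" means these few. Any claim that something is new, unique, unknown or untested is made for them only; others in the source may bear on it.

Compound 1 `CCOC(=O)/C(=C/c1ccccc1)CN1C(=O)[C@@H](OC)[C@H]1c1ccc(Cl)cc1`: "not toxic" (no number reported)
Compound 2 `CCOC(=O)/C(=C/c1ccccc1)CN1C(=O)[C@@H](OC)[C@H]1c1ccc(F)cc1`: "not toxic" (no number reported)
Compound 3 `COC(=O)/C(=C/c1ccccc1)CN1C(=O)[C@@H](OC)[C@H]1c1cccc(C(F)(F)F)c1`: 71800 nM

In an ADME assay on cells (Epithelial cell, Homo sapiens) for antiproliferative activity, read by MTT assay, with a stated time of 48 h (on this read-out lower numbers stand for stronger inhibition and higher numbers for weaker inhibition), compound 3 is the only member of this set for which a number is reported; compound 1 and compound 2 carry only the note given above, without a value. Compound 3 therefore stands alone as the reference point, and its number marks weak inhibition. Compound 4 `COC(=O)/C(=C/c1ccccc1)CN1C(=O)[C@@H](OC)[C@H]1c1ccc(OC)cc1` differs from compound 3 in a single place: 4-methoxyphenyl in place of 3-(trifluoromethyl)phenyl on a saturated ring carbon. Among the measured compounds shown here, no measured pair in this set shows such a change, so the size of the step cannot be read from the data. Given that compound 3 already sits at weak inhibition and its neighbours gave no number at all, compound 4 is expected to show no step beyond the usual scatter, or a slight drift toward weaker inhibition, a 1.3-fold higher number from compound 3 to compound 4 (0.12 log units; within the scatter). The estimate for compound 4 is 95000 nM, within a range from 30000 nM to 300000 nM.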

Compound 4, half-maximal inhibitory concentration: "not toxic" (no number reported)
The entry for compound 4 holds no number, so the estimate cannot be set against anything.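

Compound 4 gives only the note "not toxic" (no number reported) without a number, so no step from compound 3 can be read, and nothing available explains this result. The compounds shown leave open how 4-methoxyphenyl in place of 3-(trifluoromethyl)phenyl changes antiproliferative activity.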